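The source may report more compounds than this note shows. Statements on the series, on what has been measured and on what is new or still open speak of the compounds shown alone.

Compound 1 `NC1=NC2(CCOCC2)N(OCCCOc2ccc(Cl)cc2)C(N)=N1` was tested in an assay on isolated protein for inhibition of Dihydrofolate reductase (Homo sapiens), read by spectrophotometry, using NADPH, with stated times of 5 s and 6 min, tested at 5 uM; a higher number here means a stronger effect of the compound at the concentration tested, a lower number a weaker effect. In this assay compound 1 gives > 90%, which is a limit of the assay rather than a number. Compound 1 thus sits at the top of what the assay reports, as shown by the limit of > 90% in this assay, at which 1 of the 2 values shown sits. A second measured compound, compound 2 `NC1=NC2(CCSCC2)N(OCCCOc2ccccc2Cl)C(N)=N1`, gives 86.3% in this assay, so both measured compounds show strong inhibition at the tested concentration. Within the data shown here, no step between two measured compounds that differ in one place is available.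

Compound 3 `Cc1ccc(OCCCON2C(N)=NC(N)=NC23CCOCC3)cc1` has not yet been measured in this assay. It differs from compound 1 by methyl in place of chloro on an aromatic carbon. With compound 1 at a limit, the step from compound 1 to compound 3 is expected to stay within the scatter, and a number at least 5 percentage points lower from compound 1 to compound 3 (that floor lies within the scatter) is the estimated change. Compound 3 is therefore expected to give about 85% in this assay, within a range from 65% to 95%.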

Compound 3, a percentage reported as inhibition, at one concentration (the size of the read-out at that concentration, not a potency): > 90%
Compound 3: only a limit was reported; the forecaster's own chance of this, stated with the estimate: 30%; middle value at least 5 percentage points away from the limit.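

Compound 1 and compound 3 both stand at a limit of this assay and not at a number, so no step between them can be read: the limit of > 90% in this assay, at which 2 of the 3 values shown sit.

The compounds shown leave open whether methyl in place of chloro changes the inhibition at all.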